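The source may report more compounds than this note shows. Statements on the series, on what has been measured and on what is new or still open speak of the compounds shown alone.

Working notes on the thiazole acetic acid series.

In an in vitro functional assay on HEK285-7 cells for antagonist activity at prostaglandin D2 receptor 2 (Homo sapiens), read by BRET and beta-arrestin recruitment (a lower number here means a smaller maximal response, a higher number a larger maximal response), compound 1 `O=C(O)Cc1sc(C(c2ccccc2)c2ccc(Cl)cc2)nc1-c1ccc(Cl)cc1` gives 80% and compound 2 `O=C(O)Cc1sc(C(c2ccc(F)cc2)c2ccc(F)cc2)nc1-c1ccc(Cl)cc1` gives 80%; those two values lie within the usual scatter of each other. Compound 3 `N#Cc1ccc(-c2nc(C(c3ccc(F)cc3)c3ccc(F)cc3)sc2CC(=O)O)cc1` gives 30% in this assay, the lowest of the three numbers shown, with compound 1 nearest and compound 2 furthest, both beyond the scatter. Among the measured compounds shown here, the one step on record that touches the aryl group on the shared core is a number 50 percentage points lower from compound 2 to compound 3 (beyond the scatter); it shows that this position governs the maximal response strongly.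

Compound 4 `Nc1cc(-c2nc(C(c3ccc(F)cc3)c3ccc(F)cc3)sc2CC(=O)O)cc(F)n1` is not yet measured in this assay. It differs from compound 3 only here: 2-amino-6-fluoropyridin-4-yl in place of 4-cyanophenyl on an aromatic carbon. For the measured compounds named here, no measured step covers a pyridine or an amino substituent at this position, so the direction cannot be taken from the data; the step from compound 2 to compound 3 only says that a change here can be large. The starting point is the lowest value of the series, so there is more room upward than downward.

Compound 4 is therefore expected to give 45% in this assay, within 20% to 80%. The estimated change, a number 15 percentage points higher from compound 3 to compound 4 (beyond the scatter), is taken as modestly upward but with wide uncertainty.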

Compound 4, largest response reached (reported as efficacy), in percent of the reference or control that the assay uses: 30%
Beside the measured number, compound 4's estimate is 15 percentage points above it; the range from low to high includes it.
By their numbers in this assay, from the lowest: compounds 3 and 4 (each within the scatter of the next); then compounds 1 and 2 (each within the scatter of the next).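

In this assay the replacement of 4-cyanophenyl by 2-amino-6-fluoropyridin-4-yl gives no change at the digits printed from compound 3 to compound 4 (within the scatter) and so shows that the low maximal response at this position does not require a triple bond or a ring of carbon only: compound 4 has neither, and it adds a ring hetero atom and a hydrogen-bond donor. Set against the 4-chlorophenyl group, the new group gives a number 50 percentage points lower from compound 2 to compound 4 (beyond the scatter) and so repeats, with a very different aryl group, the large drop of a number 50 percentage points lower from compound 2 to compound 3 (beyond the scatter) on the same aromatic carbon. Among compound 2, compound 3 and compound 4, the 4-chlorophenyl group therefore stands apart, while the two unlike replacements sit together.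

Still open, as far as these compounds go, is what in 4-chlorophenyl goes with the larger response, which a plain phenyl or a phenyl carrying bromo or methoxy in place of the chloro could address, and whether a pyridine with the amine alone or the fluorine alone behaves like compound 4. Nothing on record explains why these two replacements sit at the same level.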